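Cyano in place of benzoyl on an indole-derived acrylic scaffold

This account rests on a few compounds, and the source may have more. Where it says the series, first, only, none or still open, it means among the compounds named here.

Measured compounds:
- compound 1, `CCOC(=O)C(=Cc1c(-c2ccccc2)[nH]c2ccccc12)C(=O)OCC`: 16900 nM
- compound 2, `O=C(/C(=C\c1c(-c2ccccc2)[nH]c2ccccc12)S(=O)(=O)c1ccccc1)c1ccccc1`: "not determined" (no result reported)
- compound 3, `COc1ccc(-c2[nH]c3ccc(OC)cc3c2C=C(C#N)C#N)cc1`: 75 nM

All three share a core built on the same aromatic bicycle with an attached chain bearing a double bond; they differ in what sits on the far end of that chain. In a functional assay on A498 cells (Homo sapiens) for inhibition, read by sulforhodamine B assay, with a stated time of 48 h (a lower number here means a stronger inhibitor of growth, a higher number a weaker inhibitor of growth), compound 1 gives 16900 nM, while compound 3 gives 75 nM. Among the compounds with values here, for compound 2 this assay holds no single number: the result is recorded as "not determined" (no result reported), so compound 2 stands nowhere on the scale yet, and no step from compound 2 can be read off.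

Compound 4, `N#C/C(=C\c1c(-c2ccccc2)[nH]c2ccccc12)S(=O)(=O)c1ccccc1`, is the next compound to be tested. It differs from compound 2 in one place: cyano in place of benzoyl on a double-bonded chain carbon bound to a double-bonded chain carbon and a sulfonyl sulfur. Cyano in place of benzoyl on a double-bonded chain carbon bound to a double-bonded chain carbon and a sulfonyl sulfur leaves the rest of compound 2 untouched.

Within the data shown here, no comparable step is recorded among the measured compounds, so the size and direction of the change in this assay cannot be taken from data; only the spread between compound 1 and compound 3 offers orientation. Compound 4 is expected to fall at about 1500 nM, between 150 nM and 15000 nM.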

Compound 4, concentration for 50% growth inhibition: 11000 nM
For compound 4 the middle estimate is 7.3-fold (0.87 log units) below the measured one; the range from low to high includes it.
By their numbers in this assay, from the lowest: compound 3; then compounds 4 and 1 (each within the scatter of the next).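

In this assay, within the data shown here, compound 4 gives 11000 nM but compound 2 is recorded as "not determined" (no result reported) and so no step between these two compounds can be read. The compounds shown leave open what placing cyano for benzoyl does to growth inhibition. No measurement here offers an explanation for the values seen.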